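A few compounds are considered here, and "the series" means these few. Any claim that something is new, unique, unknown or untested is made for them only; others in the source may bear on it.

Measured so far in an assay on microsomes from intestine for inhibition of acyl-CoA:cholesterol acyltransferase (Oryctolagus cuniculus); on this read-out lower numbers stand for stronger inhibition and higher numbers for weaker inhibition:

compound 1 `COc1ccccc1NC(=O)NCC1(c2ccccc2)CCCCC1` gives 270 nM
compound 2 `Cc1ccccc1NC(=O)NCC1(c2ccccc2)CCCCC1` gives 640 nM
compound 3 `Cc1cccc(NC(=O)NCC2(c3ccccc3)CCCCC2)c1` gives 2800 nM

Compound 3 stands highest of the three numbers in this assay: one step leading up to it is a 4.4-fold higher number from compound 2 to compound 3 (0.64 log units; beyond the scatter), and the other is a 10-fold higher number from compound 1 to compound 3 (1.02 log units; beyond the scatter), both beyond the scatter.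

The next compound, compound 4 `Cc1ccc(NC(=O)NCC2(c3ccccc3)CCCCC2)cc1`, is not yet measured. Its change from compound 3 is 4-methylphenyl in place of 3-methylphenyl on an amide-type nitrogen.

Among the measured compounds shown here, no measured step covers this change directly. The nearest is the move from 2-methylphenyl to 3-methylphenyl, which gave a 4.4-fold higher number from compound 2 to compound 3 (0.64 log units; beyond the scatter); the move from 2-methoxyphenyl to 2-methylphenyl gave a 2.4-fold higher number from compound 1 to compound 2 (0.37 log units; beyond the scatter). Both show that the placement of the methyl on the aryl group matters in this assay, but neither tells the direction for 4-methylphenyl. The expectation for compound 4 is therefore a step close to none beyond the scatter, a 1.3-fold higher number from compound 3 to compound 4 (0.10 log units; within the scatter), with wide uncertainty either way. Compound 4 is estimated at 3500 nM, in the range 900 nM to 14000 nM.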

Compound 4, half-maximal inhibitory concentration: 4500 nM
The estimate for compound 4 lay 1.3-fold (0.11 log units) below the measured number; measured number inside the range.
By their numbers in this assay, from the lowest: compound 1; then compound 2; then compounds 3 and 4 (each within the scatter of the next).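

In this assay, 4-methylphenyl in place of 3-methylphenyl on the amide-type nitrogen gives a 1.6-fold higher number from compound 3 to compound 4 (0.21 log units; within the scatter), so these two placements of the methyl cannot be told apart. The same group set against 2-methylphenyl gives a 7.0-fold higher number from compound 2 to compound 4 (0.85 log units; beyond the scatter), and set against 2-methoxyphenyl gives a 17-fold higher number from compound 1 to compound 4 (1.22 log units; beyond the scatter), so among the four aryl groups shown, 2-methylphenyl and 2-methoxyphenyl stand apart from the other two. No supporting data bear on the reason for this pattern.

The compounds shown leave open whether the methoxy group would hold its place in the order as 3-methoxyphenyl or 4-methoxyphenyl. Also open, as far as these compounds go, is how 2-ethoxyphenyl, 2-chlorophenyl or 2,6-dimethylphenyl on the same nitrogen would compare with 2-methoxyphenyl.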